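From hydroxy to nitro on compound 3

The source may report more compounds than this note shows. Statements on the series, on what has been measured and on what is new or still open speak of the compounds shown alone.

- Compound 1 `COc1cc(OC)c2sc(-c3ccc(N/C=C\C(=O)c4ccc(OC)c(O)c4)c(C)c3)nc2c1`: 3100 nM
- Compound 2 `COc1cc(OC)c2sc(-c3ccc(N/C=C\C(=O)c4ccc(OC)c([N+](=O)[O-])c4)c(C)c3)nc2c1`: 10800 nM
- Compound 3 `COc1cc(OC)c2sc(-c3ccc(N/C=C\C(=O)c4ccc(OC)c(O)c4)cc3)nc2c1`: 7610 nM

These values come from a functional assay on MDA-MB-231 cells (Homo sapiens) for antiproliferative activity, read by sulforhodamine B assay, with a stated time of 48 h; a lower number here means a stronger inhibitor, a higher number a weaker inhibitor. Compound 3 and compound 2 lie within the scatter of each other, while the gap on the other side is a 2.5-fold higher number from compound 1 to compound 3 (0.39 log units; beyond the scatter).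

Compound 4 `COc1cc(OC)c2sc(-c3ccc(N/C=C\C(=O)c4ccc(OC)c([N+](=O)[O-])c4)cc3)nc2c1` has nitro in place of hydroxy on an aromatic carbon, ortho to a methoxy group: nitro in place of hydroxy on an aromatic carbon. The same swap has been measured only once, in the pair that carries the extra methyl group: a 3.5-fold higher number from compound 1 to compound 2 (0.54 log units; beyond the scatter). With a single example as a guide, a modest step of similar size towards a higher number is expected. The expected move is a 2.9-fold higher number from compound 3 to compound 4 (0.46 log units; beyond the scatter). For compound 4 the estimate is 22000 nM, with an expected range of 10000 nM to 48000 nM.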

Compound 4, half-maximal inhibitory concentration: 12900 nM
For compound 4 the middle estimate is 1.7-fold (0.23 log units) above the measured one, and the stated range covers the measured number.
By their numbers in this assay, from the lowest: compound 1; then compounds 3, 2 and 4 (each within the scatter of the next).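

On the core without the methyl group, nitro in place of hydroxy gives a 1.7-fold higher number from compound 3 to compound 4 (0.23 log units; within the scatter), so this swap is not clearly resolved from the scatter here, though it was on the methyl-bearing core. Even so, the two measurements of the swap do not truly disagree: the same change on two cores in this assay, a 3.5-fold higher number (0.54 log units; beyond the scatter) from compound 1 to compound 2 and a 1.7-fold higher number (0.23 log units; within the scatter) from compound 3 to compound 4, 2.1-fold (0.31 log units) apart, within the scatter of two such steps

Hydrogen in place of methyl on the nitro compounds gives a 1.2-fold higher number from compound 2 to compound 4 (0.08 log units; within the scatter), and this too is compatible with the same change on the hydroxy compounds: the same change on two cores in this assay, a 2.5-fold higher number (0.39 log units; beyond the scatter) from compound 1 to compound 3 and a 1.2-fold higher number (0.08 log units; within the scatter) from compound 2 to compound 4, 2.1-fold (0.31 log units) apart, within the scatter of two such steps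

On these data alone, what an amine or a carboxylic acid would give in place of the hydroxy remains open, as does the effect of an ethyl group in place of the methyl.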